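A few compounds are considered here, and "the series" means these few. Any claim that something is new, unique, unknown or untested is made for them only; others in the source may bear on it.

Measured in a functional assay on a cell-free system (Platelet, plasma, Homo sapiens) for inhibition; on this read-out higher numbers stand for weaker inhibition and lower numbers for stronger inhibition:
- compound 1 `O=C(Nc1cccc(OCc2ccc(F)cc2)c1)C1CCNCC1`: 68000 nM
- compound 2 `O=C(Nc1cccc(OCc2ccc(-c3ccccc3F)cc2)c1)C1CCNCC1`: 62700 nM

Compound 2 stands within the scatter of compound 1, so the two numbers show no order. Compound 3 `O=C(Nc1cccc(OCc2ccc(-c3ccc(C(F)(F)F)cc3)cc2)c1)C1CCNCC1` departs from compound 2 at one place: 4-(trifluoromethyl)phenyl in place of 2-fluorophenyl on an aromatic carbon. Among the compounds with values here, only one measured step bears on this change. That step, a 1.1-fold lower number from compound 1 to compound 2 (0.04 log units; within the scatter), also put an aryl group on the same aromatic carbon and stayed within the scatter. A step beyond the scatter is therefore not expected, and the expected step is a 1.1-fold lower number from compound 2 to compound 3 (0.06 log units; within the scatter). For compound 3 the estimated value in this assay is 55000 nM, with an expected range from 25000 nM to 120000 nM.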

Compound 3, half-maximal inhibitory concentration: 65700 nM
Compound 3: middle estimate off by 1.2-fold (0.08 log units), on the low side; measured number inside the range.
By their numbers in this assay, from the lowest: compounds 2, 3 and 1 (each within the scatter of the next).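

In this assay, putting 4-(trifluoromethyl)phenyl in place of 2-fluorophenyl gives (a 1.0-fold higher number from compound 2 to compound 3 (0.02 log units; within the scatter)), and putting it in place of fluoro gives (a 1.0-fold lower number from compound 1 to compound 3 (0.01 log units; within the scatter)). This aromatic carbon has now carried fluoro and two different aryl groups, the larger of them with a trifluoromethyl group, and all three compounds lie within the scatter of one another. No measurement shown accounts for this flat read-out. Going by these compounds, it remains open whether an amine, a carboxylic acid or a longer chain at this position would give a step beyond the scatter.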